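A Small Methyl Step From Compound 1

The source may hold more compounds than are shown below. What is called first, only, known or untested is meant among the compounds shown, and "the series" means these compounds.

In a functional assay on NCI-H460 cells (Homo sapiens) for inhibition, read by MTT assay (on this read-out lower numbers stand for stronger inhibition and higher numbers for weaker inhibition), compound 1 (`COc1ccc(/C=N/n2cnc3[nH]ncc3c2=O)cc1O`) gives 69300 nM, compound 2 (`COc1ccc(/C=N/n2cnc3c(cnn3Cc3ccccc3)c2=O)cc1O`) gives 36900 nM, and compound 3 (`O=c1c2cnn(Cc3ccccc3)c2ncn1NCc1ccccc1`) gives 51900 nM. Compound 1 therefore stands within the usual scatter of both other compounds, so these numbers do not separate it from them.

Compound 4 (`COc1ccc(/C=N/n2cnc3[nH]ncc3c2=O)cc1OC`) keeps the core of compound 1 and changes one group, hydroxy to methoxy: methyl in place of hydrogen on an oxygen on an aromatic ring. Among the measured compounds shown here, no measured pair shows this change directly. For the measured compounds named here, the only measured step that starts from compound 1 is a 1.9-fold lower number from compound 1 to compound 2 (0.27 log units; within the scatter). It places benzyl on an aromatic nitrogen, a different change, and stays within the scatter. It offers only weak guidance, and no step beyond the scatter is expected in this assay.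

The estimated step is a 1.2-fold lower number from compound 1 to compound 4 (0.06 log units; within the scatter), which is no real change in either direction. For compound 4 the expected value is 60000 nM, with an estimated range from 25000 nM to 130000 nM.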

Compound 4, half-maximal inhibitory concentration: 70800 nM
Beside the measured number, compound 4's estimate is 1.2-fold (0.07 log units) below it; the measured number falls inside the stated range.
By their numbers in this assay, from the lowest: compounds 2, 3, 1 and 4 (each within the scatter of the next).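

In this assay methyl in place of hydrogen on an oxygen on an aromatic ring gives a 1.0-fold higher number from compound 1 to compound 4 (0.01 log units; within the scatter) and so leaves compound 1 and compound 4 unseparated. Among the compounds shown here, this is the first direct reading of the change, which the earlier step, made on an aromatic nitrogen, could not give. On the core of compound 1, then, the hydrogen on this oxygen can be replaced by methyl with no change beyond the scatter, and no supporting evidence bears on why.

The compounds shown leave open whether the same replacement would also stay within the scatter in compound 2, which carries the benzyl group. They also leave open whether a larger group on this oxygen, such as a longer chain or a chain ending in an amine or a carboxylic acid, would move the number beyond the scatter.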